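From compound 3 to compound 4: adding a bromo

A few compounds are considered here, and "the series" means these few. Any claim that something is new, unique, unknown or untested is made for them only; others in the source may bear on it.

Compound 1 `Cc1ccc(-c2nn(-c3ccccc3)cc2-c2nc3ccccc3[nH]2)cc1` gives 187000 nM
Compound 2 `Cc1ccc(-c2nn(-c3ccccc3)cc2-c2nc3ccccc3n2S(=O)(=O)c2ccc(Cl)cc2)cc1` gives 167000 nM
Compound 3 `O=S(=O)(c1ccccc1)n1c(-c2cn(-c3ccccc3)nc2-c2ccc(F)cc2)nc2ccccc21` gives 96300 nM

These three values come from an ADME assay on HEK-293T cells (Homo sapiens) for cytotoxicity, read by MTT assay, with a stated time of 24 h (a higher number here means that more compound is tolerated, a lower number that less compound is tolerated), and lie within the scatter of one another, so compound 3 at 96300 nM does not stand apart from compound 1 or compound 2.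

Compound 4 `O=S(=O)(c1ccc(Br)cc1)n1c(-c2cn(-c3ccccc3)nc2-c2ccc(F)cc2)nc2ccccc21` differs from compound 3 in one place. The change is bromo in place of hydrogen on an aromatic carbon, which turns phenylsulfonyl into (4-bromophenyl)sulfonyl.

Within the data shown here, no measured step isolates this change. Among the measured compounds shown here, the one measured step is a 1.1-fold lower number from compound 1 to compound 2 (0.05 log units; within the scatter) and it concerns another place, where (4-chlorophenyl)sulfonyl stands in place of hydrogen on an aromatic nitrogen. It is still the nearest guide, since it brings in a halogen on the same kind of group. Compound 3 has no such chlorine and also differs from compound 2 elsewhere, yet compound 2 at 167000 nM stays within the scatter of it.

No step beyond the scatter is therefore expected, and the estimated step is a 1.0-fold higher number from compound 3 to compound 4 (0.02 log units; within the scatter) in size. The estimate for compound 4 is 100000 nM and the range expected runs from 55000 nM up to 180000 nM in this assay once it is measured.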

Compound 4, half-maximal cytotoxic concentration: 239000 nM
Beside the measured number, compound 4's estimate is 2.4-fold (0.38 log units) below it, outside the stated range (above it).
By their numbers in this assay, from the lowest: compounds 3, 2, 1 and 4 (each within the scatter of the next, the first and the last beyond it).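

In this assay, bromo in place of hydrogen on an aromatic carbon of the phenylsulfonyl group gives a 2.5-fold higher number from compound 3 to compound 4 (0.39 log units; beyond the scatter) and so provides the first step shown that lies beyond the scatter, though a modest one. Among these compounds, the only earlier step, a 1.1-fold lower number from compound 1 to compound 2 (0.05 log units; within the scatter) on installing the whole (4-chlorophenyl)sulfonyl group on an aromatic nitrogen, stayed within the scatter and did not test a single substituent on this ring, whereas this result shows that one bromine atom on the ring, para to a large group, can shift the number towards more compound being tolerated. No measurement available here bears on what lies behind this step.

Whether this shift is particular to bromo remains open, since the compounds shown do not compare it on this same scaffold with a methoxy group, an amine or a carboxylic acid at that position. From the compounds shown here alone, it is also open whether the same replacement would produce a similar step in another compound of the series, such as one carrying the 4-methylphenyl group of compound 1 and compound 2 on the core.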